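The source may report more compounds than this note shows. Statements on the series, on what has been measured and on what is new or still open speak of the compounds shown alone.

Compound 1 (`O=c1cc(N2CCN(CC3CCC(NS(=O)(=O)c4ccccc4)CC3)CC2)sc2c([N+](=O)[O-])cc(C(F)(F)F)cc12`): 95.3%
Compound 2 (`O=c1cc(N2CCN(CC3CCCCC3)CC2)sc2c(NO)cc(C(F)(F)F)cc12`): 47.8%

Both numbers come from an ADME assay on cells (Hepatocyte, Mus musculus) for metabolic stability, with a stated time of 30 min; a higher number here means that more of the compound is left, a lower number that less of the compound is left. Compound 1 holds the higher of the two, and the gap down to compound 2 lies beyond the usual scatter. So far, then, compound 1 is the better survivor of this test, although two compounds are too few to reveal any trend.

The next compound to consider is compound 3 (`O=C(OC1CCC(CN2CCN(c3cc(=O)c4cc(C(F)(F)F)cc([N+](=O)[O-])c4s3)CC2)CC1)c1ccco1`). It keeps the rest of compound 1 and changes one group: ((furan-2-yl)carbonyl)oxy in place of (phenylsulfonyl)amino on a saturated ring carbon. Among the compounds with values here, no measured pair shows a change of this kind on its own, so any forecast is uncertain. Compound 1 at 95.3% leaves little room for a rise, while compound 2 at 47.8% shows that much lower numbers do occur among these compounds. A fall beyond the scatter is therefore expected, and the estimated change is a number 35.3 percentage points lower from compound 1 to compound 3 (beyond the scatter), though the wide range also allows a smaller fall. For compound 3 the expected value is 60%, with an estimated range from 30% to 92%.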

Compound 3, percent of the compound remaining: 0.6%
Estimate against measurement, compound 3: 59.4 percentage points above; measured number below the stated range.
By their numbers in this assay, from the lowest: compound 3; then compound 2; then compound 1.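

Within the data shown here, the swap on the saturated ring carbon gives a number 94.7 percentage points lower from compound 1 to compound 3 (beyond the scatter) in this assay, so this is the first single-place change to show that the group at this position can decide how much compound remains. The rest of the structure is the same in both compounds, which ties this large fall to the exchange of (phenylsulfonyl)amino for ((furan-2-yl)carbonyl)oxy, even though the two groups are of broadly similar size by heavy-atom count. Nothing measured here shows what happens to compound 3 in the cells, so the result describes the outcome of the swap and not the reason for it.

The swap changes two things at once, the link to the saturated ring and the aromatic ring at the end of the group, and the compounds shown cannot say which of the two accounts for the fall. A (furan-2-yl)carbonylamino group would keep the furan ring with a nitrogen link, while a benzoyloxy group would keep the oxygen link with a benzene ring, so each would test one of these two parts alone.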